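The compounds below may be only part of what the source reports. "The series", "measured", "known", "first", "only" and "open" are said of these compounds alone.

The study covers four nucleoside-like compounds examined in a functional assay on K562 cells (Homo sapiens), read by MTT assay, with a stated time of 72 h; a lower number here means a stronger inhibitor, a higher number a weaker inhibitor. Compound 1 `Cc1ncnc2c1c(-c1cc3ccccc3o1)cn2[C@@H]1O[C@H](CO)[C@@H](O)[C@H]1O` carries a 1-benzofuran-2-yl group on its core, and in this assay compound 1 gives 19500 nM. Compound 2 `Cc1ncnc2c1c(-c1ccoc1)cn2[C@@H]1O[C@H](CO)[C@@H](O)[C@H]1O` bears a furan-3-yl group on the same core. For compound 2 the result in this assay is only a limit of the assay, > 20000 nM. Compound 3 `Nc1nc(N)c2c(-c3ccoc3)cn([C@@H]3O[C@H](CO)[C@@H](O)[C@H]3O)c2n1` has a furan-3-yl group on a different core; the difference between the cores of compound 2 and compound 3 is not broken down here. For compound 3 as well, this assay returns only a limit, > 20000 nM. Two of the three values therefore rest at the limit of > 20000 nM in this assay, at which 2 of the 3 values shown sit.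

The change from compound 2 to compound 1 is 1-benzofuran-2-yl in place of furan-3-yl on an aromatic carbon, and the step it produced was an at least 1.0-fold lower number from compound 2 to compound 1 (0.01 log units; that floor lies within the scatter). Compound 4 `Nc1nc(N)c2c(-c3cc4ccccc4o3)cn([C@@H]3O[C@H](CO)[C@@H](O)[C@H]3O)c2n1` arises from compound 3 by the same change, (1-benzofuran-2-yl in place of furan-3-yl on an aromatic carbon), at the same place on the other core. With compound 3 sitting at a limit, and the earlier step itself being no more than a floor, there is little to separate the two cases. The step from compound 3 to compound 4 is expected to be a number no higher from compound 3 to compound 4 (the limit leaves the size open), on the grounds that the same exchange gave an at least 1.0-fold lower number from compound 2 to compound 1 (0.01 log units; that floor lies within the scatter) on the first core. Compound 4 is accordingly estimated at 20000 nM, with a likely range from 8000 nM to 60000 nM, and a substantial chance that only a limit is reported.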

Compound 4, half-maximal inhibitory concentration: 18600 nM
Compound 4: middle estimate off by 1.1-fold (0.03 log units), on the high side, and the stated range covers the measured number.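

In this assay, placing 1-benzofuran-2-yl where furan-3-yl stood on the core of compound 3 gave an at least 1.0-fold lower number from compound 3 to compound 4 (0.03 log units; that floor lies within the scatter). The two cores therefore give no conflicting result for this change, but this does not show that the step has the same size on both cores, or that the change brings a real gain on either: the same change on two cores in this assay, an at least 1.0-fold lower number (0.01 log units; that floor lies within the scatter) from compound 2 to compound 1 and an at least 1.0-fold lower number (0.03 log units; that floor lies within the scatter) from compound 3 to compound 4; the limit leaves it open whether they differ Both steps remain floors because each furan-3-yl compound stands at a limit of the assay, so the size of the change cannot be read on either core: the limit of > 20000 nM in this assay, at which 2 of the 4 values shown sit.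

The compounds shown leave open how other groups on the same aromatic carbon, such as a thiophene, a phenyl ring, an amine or a longer chain, would read in this assay on either core. They also leave open whether substituents on the six-membered ring of the 1-benzofuran-2-yl group would move the values on the two cores together or apart, and a pair with both members measured as numbers, rather than limits, would be needed to compare the size of any such step.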